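Urea Aryl Swap in a Pyrazole Series: Compound 4 Ahead

The source may hold more compounds than are shown below. What is called first, only, known or untested is meant among the compounds shown, and "the series" means these compounds.

Three compounds have been measured in a functional assay on CAKI-1 cells (Homo sapiens) for inhibition, read by sulforhodamine B assay, with a stated time of 48 h; a higher number here means a weaker inhibitor of growth, a lower number a stronger inhibitor of growth:

Compound 1 `O=C(Nc1cccc(-n2cc(-c3ccncc3)c(-c3ccc(Cl)c(O)c3)n2)c1)Nc1cccc(C(F)(F)F)c1` gives only a limit, > 32500 nM, in this assay.
Compound 2 `COc1cc(-c2nn(-c3cccc(NC(=O)Nc4cc(C(F)(F)F)cc(C(F)(F)F)c4)c3)cc2-c2ccncc2)ccc1Cl` gives 3140 nM in this assay.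
Compound 3 `COc1cc(-c2nn(-c3cccc(NC(=O)Nc4ccc(Cl)c(Cl)c4)c3)cc2-c2ccncc2)ccc1Cl` gives 3700 nM in this assay.

Compound 3 stands highest of the two numbers in this assay, yet compound 2 sits within the scatter of it, so the two cannot be ordered. The value of compound 1 is a limit, as stated in the limit of > 32500 nM in this assay, at which 1 of the 3 values shown sits, and is not a number to compare.

Compound 4 `COc1cc(-c2nn(-c3cccc(NC(=O)Nc4cccc(C(F)(F)F)c4)c3)cc2-c2ccncc2)ccc1Cl` differs from compound 3 in a single place: 3-(trifluoromethyl)phenyl in place of 3,4-dichlorophenyl on an amide-type nitrogen. Compound 2 shows that a trifluoromethyl-bearing phenyl on the urea, combined with the same methoxy-chloro aryl core, gives a number in the same range as the dichlorophenyl of compound 3. No measured pair differs in exactly this way, so the size of the step is unknown; on the shown data the expectation is a change of no more than the scatter, in either direction. Compound 4 is therefore expected to give 4500 nM in this assay, between 1500 nM and 15000 nM, meaning an expected step of a 1.2-fold higher number from compound 3 to compound 4 (0.09 log units; within the scatter).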

Compound 4, concentration for total growth inhibition: 3510 nM
The estimate for compound 4 lay 1.3-fold (0.11 log units) above the measured number; measured number inside the range.
By their numbers in this assay, from the lowest: compounds 2, 4 and 3 (each within the scatter of the next). At a limit, above all of these: compound 1.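

In this assay, 3-(trifluoromethyl)phenyl in place of 3,4-dichlorophenyl on the amide-type nitrogen gives a 1.1-fold lower number from compound 3 to compound 4 (0.02 log units; within the scatter), so at this position the two aryl groups cannot be told apart. The extra trifluoromethyl of compound 2 makes no readable difference either: hydrogen in place of trifluoromethyl on an aromatic carbon gives a 1.1-fold higher number from compound 2 to compound 4 (0.05 log units; within the scatter). The only step beyond the scatter lies away from the urea, where methyl in place of hydrogen on an oxygen on an aromatic ring gives an at least 9.2-fold lower number from compound 1 to compound 4 (0.96 log units; beyond the scatter), and one end of that step is the value of compound 1, which is a limit: the limit of > 32500 nM in this assay, at which 1 of the 4 values shown sits.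

The compounds shown leave open whether an ethyl group or a longer chain on that oxygen would hold the number of compound 4, and whether an amine or a carboxylic acid on the urea aryl ring would move the number beyond the scatter. From the compounds shown here alone, the full size of the step on that oxygen also stays open: one end of it is a limit and not a number.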